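The compounds below may be only part of what the source reports. "The series", "measured", "known", "first", "only" and "open" are said of these compounds alone.

Series notes. In a functional assay on KYSE-510 cells (Homo sapiens) for antiproliferative activity, read by crystal violet staining, with a stated time of 96 h (a higher number here means a weaker inhibitor of growth, a lower number a stronger inhibitor of growth), compound 1 `COc1ccc(S(=O)(=O)NC2=NCCN2C(=S)SN2CCn3c2nsc3=S)cc1` gives >= 20000 nM, which is a limit of the assay and not a number. Compound 2 `CC(=O)Nc1ccc(S(=O)(=O)NC2=NCCN2C(=S)SN2CCn3c2nsc3=S)cc1` also gives only a limit in this assay, >= 20000 nM. Compound 3 `O=[N+]([O-])c1ccc(S(=O)(=O)NC2=NCCN2C(=S)SN2CCn3c2nsc3=S)cc1` likewise returns a limit, >= 20000 nM. All three sit at the limit of >= 20000 nM in this assay, at which 3 of the 3 values shown sit, so compound 3 stands level with the others and none can be ranked. The steps a step that the two limits leave unreadable from compound 1 to compound 2, a step that the two limits leave unreadable from compound 1 to compound 3 and a step that the two limits leave unreadable from compound 2 to compound 3 are therefore of unreadable size. Compound 4 `O=S(=O)(NC1=NCCN1C(=S)SN1CCn2c1nsc2=S)c1ccc2ccccc2c1` carries naphthalen-2-yl in place of 4-nitrophenyl on a sulfonyl sulfur. Every measured step on the aryl group left the value at the limit, so no readable step bears on this change and no shift beyond the scatter is expected; the estimated step of a number no higher from compound 3 to compound 4 (the limit leaves the size open) reflects that. Compound 4 is expected at 20000 nM, within 5000 nM to 60000 nM.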

Compound 4, concentration for 50% growth inhibition: >= 20000 nM
Compound 4: only a limit was reported; the forecaster's own chance of this, stated with the estimate: 75%; the middle value lies on the limit itself.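

Compound 4, like compound 1, compound 2 and compound 3, gives only a limit in this assay, so no step to compound 4 can be read: the limit of >= 20000 nM in this assay, at which 4 of the 4 values shown sit.

The compounds shown leave open whether these aryl groups on the sulfonyl sulfur differ at all in growth inhibition.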